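The source may report more compounds than this note shows. Statements on the series, on what has been measured and on what is new or still open speak of the compounds shown alone.

Measured compounds:
- compound 1 `Cc1cc(O)c(C(=O)/C=C/c2ccc(Br)cc2)c(-c2ccccc2)c1C(=O)/C=C/c1ccc(Br)cc1`: 33500 nM
- compound 2 `Cc1cc(O)c(C(=O)/C=C/c2ccc(Cl)cc2)c(-c2ccc(OCc3ccccc3)cc2)c1C(=O)/C=C/c1ccc(Cl)cc1`: "not active" (no number reported)
- compound 3 `Cc1cc(O)c(C(=O)/C=C/c2ccc(Br)cc2)c(-c2ccc(OCc3ccccc3)cc2)c1C(=O)/C=C/c1ccc(Br)cc1`: "not active" (no number reported)

All three were tested in a functional assay on HeLa cells (Homo sapiens) for cytotoxicity, read by MTT assay, with a stated time of 24 h; on this read-out higher numbers stand for weaker inhibition and lower numbers for stronger inhibition. Only compound 1 gives a number there, 33500 nM, and that number is a weak one. Compound 3 stands without a number: in this assay compound 3 is reported as "not active" (no number reported), and compound 2 is the other entry of the same kind, with "not active" (no number reported). Going by the values given here, no step between two measured compounds is available, so the effect of any single change is unknown; what can be said is that compound 1, with a plain phenyl on the shared core, gives a measurable value and compound 3, carrying a benzyloxy, does not.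

Compound 4 `Cc1cc(O)c(C(=O)/C=C/c2ccc(Br)cc2)c(-c2ccc(Br)cc2)c1C(=O)/C=C/c1ccc(Br)cc1` has not yet been measured. Compared with compound 3 the change is bromo in place of benzyloxy on an aromatic carbon. With no shown step to lean on, the expected size of the shift in this assay cannot be taken from the data; the direction could go either way beyond the scatter, and a result with no number at all remains quite possible. Compound 4 is estimated to come out near 40000 nM, with a range from 10000 nM to 150000 nM.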

Compound 4, half-maximal inhibitory concentration: 30000 nM
Estimate against measurement, compound 4: 1.3-fold (0.12 log units) above; measured number inside the range.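

In this assay, the step of a 1.1-fold lower number from compound 1 to compound 4 (0.05 log units; within the scatter) lies within the usual scatter, so placing bromo rather than hydrogen on this aromatic carbon, para to a large group, brings no change that these data can distinguish. Compound 3, which carries benzyloxy at the same place, is reported as "not active", whereas compound 4 gives 30000 nM, so among these bromo-bearing compounds a number appears with hydrogen or bromo there but not with benzyloxy. No measurement shown explains this difference.

The step between compound 3 and compound 4 cannot be read as a size, as compound 3 has no number to set against the value of compound 4. Still open, as far as these compounds go, is how a methoxy, an amine or a carboxylic acid at this position would behave in this assay, and whether any group placed here could give a clearly lower number than hydrogen or bromo.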